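A few compounds are considered here, and "the series" means these few. Any claim that something is new, unique, unknown or untested is made for them only; others in the source may bear on it.

Compound 1 `FC(F)(F)c1ccc(CSc2nc(N3CCCCC3)c3ccccc3n2)cc1` — in a functional assay on HGC-27 cells (Homo sapiens) for cytotoxicity, read by MTT assay, with a stated time of 72 h (a lower number here means a stronger inhibitor, a higher number a weaker inhibitor), compound 1 gives > 50000 nM, which is a limit of the assay.
Compound 2 `COc1ccc(Nc2nc(SCc3ccc(C(F)(F)F)cc3)nc3ccccc23)c(OC)c1` — in this assay compound 2 gives > 50000 nM, again a limit of the assay.

Compound 2 therefore stands at the limit of > 50000 nM in this assay, at which 2 of the 2 values shown sit, and no number is known for it. Among the compounds with values here, the one measured change, a step that the two limits leave unreadable from compound 1 to compound 2, cannot be read as a size. Compound 3 `Fc1ccc(Nc2nc(SCc3ccc(C(F)(F)F)cc3)nc3ccccc23)cc1Cl` carries 3-chloro-4-fluorophenyl in place of 2,4-dimethoxyphenyl on a nitrogen on an aromatic ring. Within the data shown here, no measured step bears on this change. Compound 3 is thus expected to give 50000 nM, within 15000 nM to 100000 nM. The expected step of a number no higher from compound 2 to compound 3 (the limit leaves the size open) is none beyond the scatter, and most likely compound 3 again returns only a limit.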

Compound 3, half-maximal inhibitory concentration: 14700 nM
Estimate against measurement, compound 3: 3.4-fold (0.53 log units) above; the measured number lies below the stated range.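

The group on this nitrogen can bring activity into the readable range in this assay: 3-chloro-4-fluorophenyl in place of 2,4-dimethoxyphenyl gives an at least 3.4-fold lower number from compound 2 to compound 3 (0.53 log units; beyond the scatter). Putting (3-chloro-4-fluorophenyl)amino in place of piperidin-1-yl on the aromatic carbon gives an at least 3.4-fold lower number from compound 1 to compound 3 (0.53 log units; beyond the scatter). Compound 3 is the only one of the three with a real number, and the other two remain limits: the limit of > 50000 nM in this assay, at which 2 of the 3 values shown sit.

On these data alone, the full size of both steps stays open, as does whether the chlorine, the fluorine or the loss of the methoxy groups counts most. A phenyl carrying only chlorine, or one carrying a nitrile, would help to separate these.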